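Pyridin-2-yl Amide in Place of a Methoxycyclohexyl Amide

The source may report more compounds than this note shows. Statements on the series, on what has been measured and on what is new or still open speak of the compounds shown alone.

Measured compounds:
compound 1 `COc1cccc(OC)c1C(=O)Nc1c[nH]nc1C(=O)N[C@H]1CC[C@H](OC)CC1` – 31000 nM
compound 2 `CO[C@H]1CC[C@H](NC(=O)c2n[nH]cc2NC(=O)c2ccc(F)cc2F)CC1` – 11000 nM

Of the compounds shown here, two have been measured in an ADME assay on MRC5 cells (Homo sapiens) for inhibition, with a stated time of 72 h; on this read-out lower numbers stand for an effect already at smaller amounts and higher numbers for an effect only at larger amounts of compound. Compound 1 gives 31000 nM, the highest of the two numbers. Its nearest neighbour, compound 2, gives 11000 nM, a lower number that lies beyond the usual scatter of this assay, so the two values are separated. Among the compounds with values here, no pair of these measured compounds differs in only one place, so no single structural step can be read from them.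

The unmeasured compound 3 `COc1cccc(OC)c1C(=O)Nc1c[nH]nc1C(=O)Nc1ccccn1` shares its core with compound 1 and differs from it in one place: pyridin-2-yl in place of 4-methoxycyclohexyl on an amide-type nitrogen. Compound 1 and compound 2 differ in several places at once. The data therefore give no direct guide to what a change on the amide-type nitrogen does in this assay.

Compound 3 is therefore expected to stay close to compound 1, with a step of a 1.4-fold lower number from compound 1 to compound 3 (0.15 log units; within the scatter) that is at most modest and most likely within the scatter. The estimate for compound 3 is 22000 nM, with a range from 6000 nM to 70000 nM.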

Compound 3, half-maximal effective concentration: > 50000 nM
Compound 3 ended at the assay's limit; the forecaster's own chance of this, stated with the estimate: 15%; middle value at least 2.2-fold (0.35 log units) away from the limit.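

In this assay compound 3 gives > 50000 nM, which is a limit and not a number. Within the data shown here, this is the first change in a single place to be read at the amide-type nitrogen, and pyridin-2-yl in place of 4-methoxycyclohexyl gives an at least 1.6-fold higher number from compound 1 to compound 3 (0.20 log units; that floor lies within the scatter), so this aromatic ring does not move the number downward, though the floor of the step alone does not separate the two compounds. How large the step really is cannot be said because the value for compound 3 is capped, and the position is shown to tolerate no more than this one reading: the limit of > 50000 nM in this assay, at which 1 of the 3 values shown sits.

The compounds shown leave open whether a cyclohexyl ring without the methoxy group, a piperidine ring or an open alkyl chain on this nitrogen would bring the number down or push it up. They also leave open whether pyridin-2-yl would give a step in the same direction on the core of compound 2, which carries a difluorobenzoyl group rather than the dimethoxybenzoyl group of compound 1.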